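Trimming neopentyl to isopropyl in compound 3

The source may report more compounds than this note shows. Statements on the series, on what has been measured and on what is new or still open speak of the compounds shown alone.

Among the measured compounds shown here, in a functional assay for inhibition, with Rattus norvegicus as the target (on this read-out higher numbers stand for weaker inhibition and lower numbers for stronger inhibition), three compounds have numbers so far. Compound 3 (`CC(C)(C)CN/C(=C\[N+](=O)[O-])Nc1cccnc1`) gives 1000 nM and sits in the middle of the three, with compound 1 (`C[C@H](/N=C(/S)Nc1ccncc1)C(C)(C)C`) at 316 nM on the lower side and compound 2 (`CC(C)(C)CN/C(=C\[N+](=O)[O-])Nc1ccncc1`) at 10000 nM on the higher side.

The next compound to be tested is compound 4 (`CC(C)N/C(=C\[N+](=O)[O-])Nc1cccnc1`), which carries isopropyl in place of neopentyl on an amine nitrogen. The full count of that change is as follows: isopropyl in place of neopentyl on an amine nitrogen and nothing else differs.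

For the measured compounds named here, only one measured step links two compounds that differ in a single place: a 10-fold lower number from compound 2 to compound 3 (1.00 log units; beyond the scatter) for pyridin-3-yl in place of pyridin-4-yl on an amine nitrogen. That step shows that one small swap can matter in this series, but it concerns a different place, so it gives no direct guide to the neopentyl group. Going by the values given here, no measured pair tests that group alone, which makes any direction a cautious guess. A modest rise in the number seems the likeliest outcome, and the expected move is a 3.0-fold higher number from compound 3 to compound 4 (0.48 log units; beyond the scatter) in this assay as a rough estimate. Compound 4 is estimated at 3000 nM with 1000 nM to 10000 nM as the expected range.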

Compound 4, half-maximal inhibitory concentration: 31600 nM
Compound 4: the middle estimate sits 11-fold (1.02 log units) below what was measured; the measured number lies above the stated range.
By their numbers in this assay, from the lowest: compound 1; then compound 3; then compound 2; then compound 4.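

In this assay, trimming neopentyl to isopropyl on the amine nitrogen gives a 32-fold higher number from compound 3 to compound 4 (1.50 log units; beyond the scatter), which means weaker inhibition. Among the compounds shown here, the only earlier step, a 10-fold lower number from compound 2 to compound 3 (1.00 log units; beyond the scatter), concerned the pyridine end, so this result is the first to show that the group on this amine nitrogen also strongly affects the number; here, the smaller group, with 3 heavy atoms against 5, goes with the weaker inhibition. No measurement available here explains why the number moves so far, and this one pair cannot separate the loss of size from the change in the shape of the group.

The compounds shown leave open whether neopentyl is specially suited to this place or whether other groups would serve as well or better, such as a straight pentyl chain, a tert-butyl group or a cyclohexyl ring. They also leave open whether the same trim from neopentyl to isopropyl would have a similar effect with pyridin-4-yl in place of pyridin-3-yl on the other amine nitrogen.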